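A few compounds are considered here, and "the series" means these few. Any claim that something is new, unique, unknown or untested is made for them only; others in the source may bear on it.

- Compound 1 `COc1ccc(/C=C2\CCC/C(=C\c3cccc(Cl)c3)C2=O)cc1OC`: 5100 nM
- Compound 2 `COc1cccc(/C=C2\CCC/C(=C\c3ccc(OC)c(OC)c3)C2=O)c1`: 3700 nM

Going by the values given here, in a functional assay on SW-620 cells (Homo sapiens) for cytotoxicity, read by MTT assay, with a stated time of 72 h (on this read-out higher numbers stand for weaker inhibition and lower numbers for stronger inhibition), compound 2 cannot be told apart from compound 1, as the only measured step shows: a 1.4-fold lower number from compound 1 to compound 2 (0.14 log units; within the scatter). Among the compounds with values here, that step, methoxy in place of chloro on an aromatic carbon, is the only guide to compound 3 `COc1ccc(/C=C2\CCC/C(=C\c3ccc(Cl)c(Cl)c3)C2=O)cc1OC`, which is not yet measured. The change to it is 3,4-dichlorophenyl in place of 3-methoxyphenyl on a double-bonded chain carbon bound to a double-bonded ring carbon. It swaps a whole ring substituent pattern, so the guide is loose, but no shift beyond the scatter is expected in this assay. The expected step is a 1.2-fold higher number from compound 2 to compound 3 (0.09 log units; within the scatter). For compound 3, the estimated value is 4500 nM, within a range of 1800 nM to 11000 nM.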

Compound 3, half-maximal inhibitory concentration: 4000 nM
The estimate for compound 3 lay 1.1-fold (0.05 log units) above the measured number, within the range that was stated.
By their numbers in this assay, from the lowest: compounds 2, 3 and 1 (each within the scatter of the next).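

Three different ring patterns now sit within the scatter of one another in this assay. Putting 3,4-dichlorophenyl in place of 3-methoxyphenyl on a double-bonded chain carbon bound to a double-bonded ring carbon gives a result that cannot be told apart (a 1.1-fold higher number from compound 2 to compound 3 (0.03 log units; within the scatter)), and the same holds for chloro in place of hydrogen on an aromatic carbon (a 1.3-fold lower number from compound 1 to compound 3 (0.11 log units; within the scatter)). No supporting measurement is available to explain this.

Going by these compounds, it remains open whether a ring bearing an amine or a carboxylic acid would also read the same in this assay.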